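Bromo for Fluoro on the Anilino Ring of Compound 2

The source may report more compounds than this note shows. Statements on the series, on what has been measured and on what is new or still open speak of the compounds shown alone.

Compound 1 `Fc1cccc(-c2nc(Nc3ccccc3)c3ccccc3n2)c1`: > 50000 nM
Compound 2 `Fc1cccc(Nc2nc(-c3cccc(F)c3)nc3ccc(F)cc23)c1`: 49600 nM

Of the compounds shown here, two have been measured in a functional assay on U2OS cells (Homo sapiens) for cytotoxicity, read by MTT assay, with a stated time of 48 h; a lower number here means a stronger inhibitor, a higher number a weaker inhibitor. Compound 1 gives only a limit of the assay, > 50000 nM. Of the two values shown, one sits at the limit of > 50000 nM in this assay, at which 1 of the 2 values shown sits, and that is the value of compound 1. Among the compounds with values here, compound 2 is therefore the only compound with a number: in this assay compound 2 gives 49600 nM, a weak result.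

Compound 3 `Fc1cccc(-c2nc(Nc3cccc(Br)c3)c3cc(F)ccc3n2)c1` differs from compound 2 in one place: bromo in place of fluoro on an aromatic carbon. Within the data shown here, no step between measured compounds is available, so the size of the change can only be guessed. Since compound 2 gives 49600 nM, compound 3 is expected to remain a weak inhibitor, with a step from compound 2 to compound 3 of a 1.4-fold lower number from compound 2 to compound 3 (0.15 log units; within the scatter), most likely within the scatter. The estimate for compound 3 is 35000 nM, between 10000 nM and 100000 nM.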

Compound 3, half-maximal inhibitory concentration: > 50000 nM
Compound 3 was reported as a limit; the forecaster's own chance of this, stated with the estimate: 35%; at least 1.4-fold (0.15 log units) between middle value and limit.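

In this assay, within the data shown here, the change from (3-fluorophenyl)amino to (3-bromophenyl)amino gives the first step at this position, and it brings no gain in strength: a number no lower from compound 2 to compound 3 (the limit leaves the size open). The value of compound 3, > 50000 nM, is a limit and not a number, so the size of this step cannot be read. The result adds a second compound at the limit: the limit of > 50000 nM in this assay, at which 2 of the 3 values shown sit.

The compounds shown leave open whether an amine, a methoxy or a carboxylic acid on this aromatic carbon would give a clearly lower number than compound 2 does. They also leave open whether bromo in place of fluoro would have any readable effect on a compound that starts from a stronger value, away from the limit of this assay.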